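The compounds below may be only part of what the source reports. "The series", "measured", "known", "first", "only" and "open" are said of these compounds alone.

Measured so far:
- compound 1, `COc1cc(N2CCN(C)CC2)ccc1Nc1ncc(Cl)c(Oc2cccc(NC(=O)CCN3CCCC3)c2)n1`: 1890 nM
- compound 2, `COc1cc(N2CCN(C)CC2)ccc1Nc1ncc(Cl)c(Oc2cccc(NC(=O)CCN3CCCCC3)c2)n1`: 365 nM

Both compounds were tested in a functional assay on BEAS-2B cells (Homo sapiens) for antiproliferative activity, read by MTT assay, with a stated time of 72 h; a lower number here means a stronger inhibitor, a higher number a weaker inhibitor. Among the measured compounds shown here, of the two numbers, compound 2 has the lower one, and the only neighbour is compound 1 with a higher number. For the measured compounds named here, the one step available, a 5.2-fold lower number from compound 1 to compound 2 (0.71 log units; beyond the scatter), is the change from the smaller ring to the larger one at the end of the chain.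

Compound 3, `COc1cc(N2CCN(C)CC2)ccc1Nc1ncc(Cl)c(Oc2cccc(NC(=O)CCN3CCN(C)CC3)c2)n1`, has not yet been tested. It differs from compound 2 in one place: 4-methylpiperazin-1-yl in place of piperidin-1-yl on a saturated chain carbon, two bonds along the chain from a carbonyl carbon. This is a different kind of change from the one measured: the ring size stays the same and instead one ring member changes. The step from compound 1 to compound 2 therefore bears on it only loosely, as a sign that this part of the molecule does affect the number in this assay. Going by the values given here, with no direct precedent, the expectation for compound 3 is a number close to that of compound 2, with a step of a 1.4-fold higher number from compound 2 to compound 3 (0.14 log units; within the scatter) that may well lie within the scatter. The estimated value for compound 3 in this assay is 500 nM, expected to fall between 150 nM and 1700 nM.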

Compound 3, half-maximal inhibitory concentration: 412 nM
Compound 3: middle estimate off by 1.2-fold (0.08 log units), on the high side; low and high end bracket the measured number.
By their numbers in this assay, from the lowest: compounds 2 and 3 (each within the scatter of the next); then compound 1.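

In this assay, exchanging piperidin-1-yl for 4-methylpiperazin-1-yl gives a 1.1-fold higher number from compound 2 to compound 3 (0.05 log units; within the scatter), so compound 2 and compound 3 cannot be told apart, and this position accepts a second ring nitrogen carrying a methyl group with no measurable cost. The comparison with the five-membered pyrrolidin-1-yl ring gives a 4.6-fold lower number from compound 1 to compound 3 (0.66 log units; beyond the scatter), which stands alongside a 5.2-fold lower number from compound 1 to compound 2 (0.71 log units; beyond the scatter), so among these three compounds both six-membered rings go with a lower number than the five-membered ring, and none goes against this. No independent measurement is available to explain these numbers.

The compounds shown leave open whether this tolerance extends to other groups at the end of the chain, such as morpholin-4-yl, the seven-membered azepan-1-yl ring or an open-chain dimethylamino group. On these data alone, all three compounds also share the same chain between the carbonyl and the ring, so the effect of a longer chain on these ring comparisons remains unknown.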